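The source may hold more compounds than are shown below. What is called first, only, known or untested is meant among the compounds shown, and "the series" means these compounds.

Compounds with numbers in hand:
compound 1 `C#CCCOC(=O)C1=C(C)NC(C)=C(C(=O)OC)C1c1cccc([N+](=O)[O-])c1` – 31 nM
compound 2 `COC(=O)C1=C(C)NC(C)=C(C(=O)OCc2cc([N+](=O)[O-])cc([N+](=O)[O-])c2)C1c1cccc([N+](=O)[O-])c1` – 55 nM
compound 3 `COC(=O)C1=C(C)NC(C)=C(C(=O)OCc2ccc(OC)c(OC)c2)C1c1cccc([N+](=O)[O-])c1` – 112 nM

In a functional assay on HEK293 cells for antagonist activity at Voltage-dependent L-type calcium channel subunit alpha-1C (Oryctolagus cuniculus), read by FLIPR (a higher number here means a weaker inhibitor, a lower number a stronger inhibitor), compound 3 stands at the highest number of the three: a 2.0-fold higher number from compound 2 to compound 3 (0.31 log units; beyond the scatter) and a 3.6-fold higher number from compound 1 to compound 3 (0.56 log units; beyond the scatter). Compound 4 `COC(=O)C1=C(C)NC(C)=C(C(=O)OCCOc2ccccc2Cl)C1c1cccc([N+](=O)[O-])c1` differs from compound 3 by (2-chlorophenoxy)methyl in place of 3,4-dimethoxyphenyl on a saturated chain carbon bound to an oxygen next to a carbonyl group. Within the data shown here, no measured step makes this exact swap; the nearest guide is the exchange of one aryl group for another at the same place, which gave a modest shift, a 2.0-fold higher number from compound 2 to compound 3 (0.31 log units; beyond the scatter), while a 1.8-fold higher number from compound 1 to compound 2 (0.25 log units; within the scatter) stayed within the scatter. On that basis a small step toward a lower number, or none beyond the scatter, is expected in this assay. Compound 4 is therefore estimated at 80 nM, with a likely range from 25 nM to 250 nM, which is expected to mean a 1.4-fold lower number from compound 3 to compound 4 (0.15 log units; within the scatter).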

Compound 4, half-maximal inhibitory concentration: 19 nM
Beside the measured number, compound 4's estimate is 4.2-fold (0.62 log units) above it, and the stated range ends above it.
By their numbers in this assay, from the lowest: compounds 4, 1 and 2 (each within the scatter of the next, the first and the last beyond it); then compound 3.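

In this assay, among these compounds, the change to 2-(2-chlorophenoxy)ethyl at this place brings a 5.9-fold lower number from compound 3 to compound 4 (0.77 log units; beyond the scatter) and also a 2.9-fold lower number from compound 2 to compound 4 (0.46 log units; beyond the scatter) so this group reads better than both substituted benzyl groups, which the earlier compounds could not show. Against the ethynyl-ended chain the step is a 1.6-fold lower number from compound 1 to compound 4 (0.21 log units; within the scatter) so the two chains cannot be told apart here. Nothing available explains these steps. The compounds shown do not separate the chlorine from the ether oxygen. They also leave open how a plain 2-phenoxyethyl group or a chain carrying an amine would read in this assay.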